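The source may hold more compounds than are shown below. What is called first, only, known or untested is meant among the compounds shown, and "the series" means these compounds.

Measured so far in a functional assay on Hep 3B2 cells (Homo sapiens) for antiproliferative activity, read by MTT assay, with a stated time of 24 h, tested at 33.33 ug/mL; on this read-out lower numbers stand for a weaker effect and higher numbers for a stronger effect at the one concentration tested:

Compound 1, `Cc1ccc2nc(C(=O)Nc3c(F)cc(-c4cccc(F)c4)cc3F)c(C)c(O)c2c1`: 37.3%
Compound 2, `CCc1ccc2nc(C(=O)Nc3c(F)cc(-c4cccc(F)c4)cc3F)c(C)c(O)c2c1`: 56.3%
Compound 3, `CCOc1ccc2nc(C(=O)Nc3c(F)cc(-c4cccc(F)c4)cc3F)c(C)c(C(=O)O)c2c1`: 38.7%

Compound 1 and compound 2 share a core and differ only in one place: hydrogen in place of methyl on a saturated chain carbon bound to an aromatic carbon. This change gave a number 19 percentage points lower from compound 2 to compound 1 (beyond the scatter). Compound 3 carries a different core; how the two cores differ is not broken down here, and compound 3 and compound 2 are simply two separately measured points. Compound 4, `COc1ccc2nc(C(=O)Nc3c(F)cc(-c4cccc(F)c4)cc3F)c(C)c(C(=O)O)c2c1`, has not yet been measured. It differs from compound 3 as follows: hydrogen in place of methyl on a saturated chain carbon bound to an oxygen on an aromatic ring. Among the measured compounds shown here, this is the same kind of change as the one from compound 2 to compound 1, but not the same: there the place was on a saturated chain carbon bound to an aromatic carbon, here it is on a saturated chain carbon bound to an oxygen on an aromatic ring. Resting on the single earlier step, a drop of similar direction but uncertain size is expected, a number 9.7 percentage points lower from compound 3 to compound 4 (within the scatter). For compound 4 the estimate in this assay is 29%, with a range from 14% to 45%.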

Compound 4, a percentage reported as inhibition, at one concentration (the size of the read-out at that concentration, not a potency): 7.24%
Compound 4: the middle estimate sits 21.8 percentage points above what was measured; measured number below the stated range.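

Shortening the ethoxy group to methoxy gave a number 31.5 percentage points lower from compound 3 to compound 4 (beyond the scatter) in this assay. Set beside the earlier shortening of ethyl to methyl on the other core, the change points the same way, and the two sizes cannot be told apart: the same change on two cores in this assay, a number 19 percentage points lower (beyond the scatter) from compound 2 to compound 1 and a number 31.5 percentage points lower (beyond the scatter) from compound 3 to compound 4, 12.5 percentage points apart, within the scatter of two such steps. Within these two pairs, then, removing one methyl from the end of a short chain goes with a lower number on both cores, whether the chain is bound to an aromatic carbon or to an oxygen on an aromatic ring, but two pairs do not show that the drop would carry to a further core or that its size is fixed.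

The compounds shown leave open how a longer chain such as propyl, or an amine at the same place, would read on either core. Each number also comes from one concentration, so these steps speak only of a stronger or weaker effect at that concentration.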